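Ester substituent variation on the shared core

A few compounds are considered here, and "the series" means these few. Any claim that something is new, unique, unknown or untested is made for them only; others in the source may bear on it.

The three measured compounds share one core and differ only at the ester carbonyl carbon: compound 1 `Cc1ccc(C(=O)OC2(C(=O)Nc3ccc([N+](=O)[O-])cc3)CCCCC2)cc1` carries a 4-methylphenyl there, compound 2 `O=C(OC1(C(=O)Nc2ccc([N+](=O)[O-])cc2)CCCCC1)c1ccc(Br)cc1` a 4-bromophenyl, and compound 3 `O=COC1(C(=O)Nc2ccc([N+](=O)[O-])cc2)CCCCC1` a hydrogen. In a functional assay on HepG2 cells (Homo sapiens) for inhibition, read by MTT assay, with a stated time of 72 h (a higher number here means a weaker inhibitor, a lower number a stronger inhibitor), compound 1 gives 61.2 nM, compound 2 gives 284 nM and compound 3 gives 34.1 nM. Between the two aryl esters there is a 4.6-fold higher number from compound 1 to compound 2 (0.67 log units; beyond the scatter). Compound 3 stands at the lowest of the three numbers, although its gap to compound 1 lies within the scatter (a 1.8-fold lower number from compound 1 to compound 3 (0.25 log units; within the scatter)), while its gap to compound 2 lies beyond it (an 8.3-fold lower number from compound 2 to compound 3 (0.92 log units; beyond the scatter)).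

Compound 4 `O=C(OC1(C(=O)Nc2ccc([N+](=O)[O-])cc2)CCCCC1)C(O)c1ccccc1` differs from compound 3 by hydroxy(phenyl)methyl in place of hydrogen on a carbonyl carbon. The two steps that bear on this are the ones at the same carbonyl carbon, a 1.8-fold lower number from compound 1 to compound 3 (0.25 log units; within the scatter) and an 8.3-fold lower number from compound 2 to compound 3 (0.92 log units; beyond the scatter); read in reverse, placing a substituent on that carbon has so far given a within-scatter to modest rise in number. A modest rise is therefore expected in this assay, estimated as a 2.5-fold higher number from compound 3 to compound 4 (0.40 log units; beyond the scatter). For compound 4 the expected value is 85 nM, with a range from 28 nM to 300 nM.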

Compound 4, half-maximal inhibitory concentration: 7.7 nM
Beside the measured number, compound 4's estimate is 11-fold (1.04 log units) above it; the measured number lies below the stated range.
By their numbers in this assay, from the lowest: compound 4; then compounds 3 and 1 (each within the scatter of the next); then compound 2.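

The carbonyl carbon is not a place where substitution only holds the number level or raises it: in this assay the step to hydroxy(phenyl)methyl gives a 4.4-fold lower number from compound 3 to compound 4 (0.65 log units; beyond the scatter) and so runs against the 4-bromophenyl group, which stood higher than hydrogen, and against the 4-methylphenyl group, which stood within the scatter of it. The new group also separates from both aryl groups, with a 7.9-fold lower number from compound 1 to compound 4 (0.90 log units; beyond the scatter) and a 37-fold lower number from compound 2 to compound 4 (1.57 log units; beyond the scatter) and compound 4 is the strongest inhibitor of the four in this assay. No measurement shown gives a reason for this change.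

The compounds shown do not tell whether the hydroxy or the phenyl of hydroxy(phenyl)methyl carries the fall in number. A benzyl group or a hydroxymethyl group on the same carbonyl carbon would separate the two, and an amine in place of the hydroxy would test whether the oxygen is needed at all.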